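The compounds below may be only part of what the source reports. "The series", "measured", "known", "first", "only" and "open" are said of these compounds alone.

Measured so far:
compound 1 `ClCc1ccccc1Cn1cnc2c(Cl)nc(Cl)nc21`: 2950 nM
compound 2 `ClCc1ccccc1Cn1cnc2c(Cl)ncnc21`: 34700 nM
compound 3 `ClCc1cccc(Cn2cnc3c(Cl)ncnc32)c1`: 24000 nM

In a functional assay on DU-145 cells (Homo sapiens) for cytotoxicity, read by sulforhodamine B assay, with a stated time of 48 h (a lower number here means a stronger inhibitor of growth, a higher number a weaker inhibitor of growth), compound 2 gives the highest of the three numbers. Within the data shown here, compound 3 is close to it, within the scatter, while compound 1 stands well apart: a 12-fold higher number from compound 1 to compound 2 (1.07 log units; beyond the scatter) is the only step that touches the carbon now in question. Compound 4 `Nc1nc(Cl)c2ncn(Cc3ccccc3CCl)c2n1` differs from compound 2 by amino in place of hydrogen on an aromatic carbon. Among the measured compounds shown here, no measured pair exchanges hydrogen for amino, so the single relevant step only shows that this carbon tolerates a substituent with a large shift; an amino group is not a chloro group, and the direction cannot be read from it with confidence. A moderate improvement is expected, a 2.9-fold lower number from compound 2 to compound 4 (0.46 log units; beyond the scatter), giving an estimate for compound 4 of 12000 nM within 2500 nM to 60000 nM.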

Compound 4, concentration for total growth inhibition: 32400 nM
The estimate for compound 4 lay 2.7-fold (0.43 log units) below the measured number; low and high end bracket the measured number.
By their numbers in this assay, from the lowest: compound 1; then compounds 3, 4 and 2 (each within the scatter of the next).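

In this assay, amino in place of hydrogen on this aromatic carbon, between two ring nitrogen atoms, leaves the number within the scatter (a 1.1-fold lower number from compound 2 to compound 4 (0.03 log units; within the scatter)). Chloro on the same carbon stands apart from amino (an 11-fold higher number from compound 1 to compound 4 (1.04 log units; beyond the scatter)), so among these three groups only chloro gives a clearly stronger growth inhibitor. Nothing measured here explains this difference. Going by these compounds, whether fluoro, methyl or hydroxyl on this carbon would match chloro or instead match hydrogen and amino stays open. So does whether amino would change the number on the core of compound 3.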